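Swapping the benzyl substituent on a nucleoside scaffold

This account rests on a few compounds, and the source may have more. Where it says the series, first, only, none or still open, it means among the compounds named here.

The measured compounds:
compound 1, `OC[C@H]1O[C@@H](n2cnc3c(NCc4ccccc4F)ncnc32)[C@H](O)[C@@H]1O`, > 166000 nM
compound 2, `OC[C@H]1O[C@@H](n2cnc3c(NCc4cccc(F)c4)ncnc32)[C@H](O)[C@@H]1O`, "not determined" (no result reported)
compound 3, `Cc1cccc(CNc2ncnc3c2ncn3[C@@H]2O[C@H](CO)[C@@H](O)[C@H]2O)c1`, > 166000 nM

All three share one core, a sugar-linked purine carrying a benzyl-type group on a nitrogen, and differ only in the substituent on that benzyl ring. In a functional assay on B16 cells (Mus musculus) for antiproliferative activity, with a stated time of 72 h (a higher number here means a weaker inhibitor, a lower number a stronger inhibitor), compound 1 gives only a limit, > 166000 nM, not a number. Compound 3 likewise gives only a limit, > 166000 nM, in this assay. For compound 2 no result was reported in this assay. For the measured compounds named here, the one step between measured compounds, a step that the two limits leave unreadable from compound 1 to compound 3, therefore cannot be sized, since the limit of > 166000 nM in this assay, at which 2 of the 3 values shown sit, means neither compound showed measurable inhibition.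

Compound 4, `OC[C@H]1O[C@@H](n2cnc3c(NCc4ccc(Cl)cc4Cl)ncnc32)[C@H](O)[C@@H]1O`, has not yet been measured. It differs from compound 1 by 2,4-dichlorophenyl in place of 2-fluorophenyl on a saturated chain carbon bound to a nitrogen on an aromatic ring. Going by the values given here, the only comparison available, from compound 1 to compound 3, changed the same ring substituent and left both compounds at the limit. Among the compounds with values here, no measured step indicates any direction for this assay, so compound 4 is expected to sit at the limit as well, with an expected step of a number no higher from compound 1 to compound 4 (the limit leaves the size open). The estimate for compound 4 in this assay is 166000 nM, in a range from 40000 nM to 700000 nM.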

Compound 4, half-maximal inhibitory concentration: > 166000 nM
Compound 4 gave a limit, no number (the forecaster's own chance of this, stated with the estimate: 80%); the middle value sits exactly at the limit.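

In this assay compound 4 also gives only a limit, > 166000 nM, not a number. For the compounds shown here, no step among compound 1, compound 3 and compound 4 can therefore be read: the limit of > 166000 nM in this assay, at which 3 of the 4 values shown sit. The compounds shown leave open whether any benzyl substituent on the shared core gives a measurable value in this assay.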